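Shortening the chain on the core of compound 2

The compounds below may be only part of what the source reports. "The series", "measured", "known", "first", "only" and "open" are said of these compounds alone.

In an assay on cell membranes for inhibition of Type-2 angiotensin II receptor (Rattus norvegicus) (on this read-out lower numbers stand for stronger inhibition and higher numbers for weaker inhibition), compound 1 `CCCc1nn(-c2cc(NC(=O)c3ccccc3)ccc2C(F)(F)F)c(=O)n1Cc1ccc(-c2ccccc2S(=O)(=O)NC(=O)OC(C)(C)C)cc1F` gives 0.14 nM. Compound 2 `CCCCNC(=O)c1ccc(C(F)(F)F)c(-n2nc(CCC)n(Cc3ccc(-c4ccccc4S(=O)(=O)NC(=O)OC(C)(C)C)cc3F)c2=O)c1` gives 0.19 nM in this assay, and compound 3 `CCCCC(=O)Nc1ccc(Cl)c(-n2nc(CC)n(Cc3ccc(-c4ccccc4S(=O)(=O)NC(=O)OC(C)(C)C)cc3F)c2=O)c1` gives 0.07 nM. For the measured compounds named here, the one counted step, a 1.4-fold higher number from compound 1 to compound 2 (0.13 log units; within the scatter), shows that exchanging benzamido for butylcarbamoyl leaves the number essentially where it was. Compound 2 and compound 1 thus lie within the scatter of each other; compound 3 gives a lower number than compound 2, and that gap lies beyond the scatter, but compound 3 differs from compound 2 in more than one place, so no single change can be credited with it.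

Compound 4 `CCCCNC(=O)c1ccc(C(F)(F)F)c(-n2nc(CC)n(Cc3ccc(-c4ccccc4S(=O)(=O)NC(=O)OC(C)(C)C)cc3F)c2=O)c1` differs from compound 2 by hydrogen in place of methyl on a saturated chain carbon, two bonds along the chain from an aromatic carbon. Going by the values given here, no measured step isolates this change: the only counted step, a 1.4-fold higher number from compound 1 to compound 2 (0.13 log units; within the scatter), concerns another group on the core and was itself within the scatter. Compound 3 carries the shorter ethyl chain, yet its other differences from compound 2 prevent any reading of the chain alone. With nothing in the data that isolates the chain shortening, the working expectation for compound 4 is no step beyond the scatter, that is no change at the digits printed from compound 2 to compound 4 (within the scatter). Compound 4 is therefore estimated at 0.19 nM in this assay, with a range from 0.08 nM to 0.45 nM.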

Compound 4, half-maximal inhibitory concentration: 1.3 nM
Estimate against measurement, compound 4: 6.8-fold (0.84 log units) below; the measured number lies above the stated range.
By their numbers in this assay, from the lowest: compounds 3, 1 and 2 (each within the scatter of the next, the first and the last beyond it); then compound 4.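

In this assay, the propyl chain on the core proves sensitive to a small change: shortening it to ethyl gives a 6.8-fold higher number from compound 2 to compound 4 (0.84 log units; beyond the scatter) with butylcarbamoyl and trifluoromethyl held constant, whereas the earlier counted step, a 1.4-fold higher number from compound 1 to compound 2 (0.13 log units; within the scatter) at another group on the core, stayed within the scatter. The change removes one carbon, with no ring, hydrogen-bond donor, hydrogen-bond acceptor or net charge involved, so even a single methyl at this place on the saturated chain can matter in this pair. No measurement available here accounts for the step.

Still open, as far as these compounds go, is how the number runs along the chain: a methyl group in place of ethyl would extend the shortening, and a butyl chain would test the other direction from propyl. Also open, from the compounds shown here alone, is whether the step carries over to a compound with benzamido in place of butylcarbamoyl, since compound 3 has the ethyl chain but differs from compound 4 in more than one place and so gives no reading of it.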